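Dinonyl aminoglycoside core with an acyclic replacement

This account rests on a few compounds, and the source may have more. Where it says the series, first, only, none or still open, it means among the compounds named here.

Compound 1 `CCCCCCCCCO[C@@H]1[C@@H](N)[C@@H](O[C@H]2[C@H](O)[C@@H](O)[C@H](N)C[C@@H]2N)O[C@H](CN)[C@H]1OCCCCCCCCC` was examined in a toxicity assay on the whole organism (J774 cells) for cytotoxicity, with Mus musculus as the target, read by MTT assay, with a stated time of 24 h, tested at 30 uM; a higher number here means a weaker effect of the compound at the concentration tested, a lower number a stronger effect. In this assay compound 1 gives 48.6%, the highest of the three numbers measured. The nearest number belongs to compound 3 `CCCCCCCCCO[C@@H]1[C@@H](N)[C@@H](O[C@H]2[C@H](O)[C@@H](OCCCCCCCCC)[C@H](N)C[C@@H]2N)O[C@H](CN)[C@H]1O`, which in this assay gives 38.8%, a gap to compound 1 within the usual scatter. The furthest belongs to compound 2 `C=CCO[C@H]1O[C@H](CN)[C@@H](OCc2ccc3ccccc3c2)[C@H](OCc2ccc3ccccc3c2)[C@H]1N`, which in this assay gives 28.3%, a gap beyond the scatter. Compound 4 `CCCCCCCCCO[C@@H]1[C@@H](N)[C@@H](OCC(O)CNCCO)O[C@H](CN)[C@H]1OCCCCCCCCC` has not been measured. It differs from compound 1 in one place: 2-hydroxy-3-((2-hydroxyethyl)amino)propyl in place of 4,6-diamino-2,3-dihydroxycyclohexyl on an oxygen on a saturated carbon. Among the compounds with values here, no pair of measured compounds isolates this change, so the data give no size for it in either direction. The step of a number 1.4 percentage points higher from compound 1 to compound 4 (within the scatter) is therefore expected to be none beyond the scatter. Compound 4 is estimated to give 50% in this assay, with a range from 30% to 72%.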

Compound 4, a percentage reported as activity, at one concentration (the size of the read-out at that concentration, not a potency): 10.1%
Compound 4: middle estimate off by 39.9 percentage points, on the high side; the whole stated range lies above it.
By their numbers in this assay, from the lowest: compound 4; then compound 2; then compounds 3 and 1 (each within the scatter of the next).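

At the oxygen on a saturated carbon, the core of compound 1 does not tolerate this exchange neutrally: in this assay, 2-hydroxy-3-((2-hydroxyethyl)amino)propyl in place of 4,6-diamino-2,3-dihydroxycyclohexyl gives a number 38.5 percentage points lower from compound 1 to compound 4 (beyond the scatter), which means a stronger effect at the concentration tested. Within the data shown here, this is the first size available for any change at this position, and it is a large one. Nothing measured here explains the step.

As far as these compounds go, it remains open whether the step follows from losing the ring or from the chain that enters. A simple aminoethyl chain or a carboxylic acid on the same oxygen would help separate the two.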